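Chain-extended tetrazole ketones as cysteinyl leukotriene antagonists

A few compounds are considered here, and "the series" means these few. Any claim that something is new, unique, unknown or untested is made for them only; others in the source may bear on it.

Measured compounds:
compound 1, `CCCc1c(COc2ccc(C(=O)Cc3nnn[nH]3)cc2)ccc(C(C)=O)c1O`, 7.71
compound 2, `CCCc1c(COc2ccc(C(=O)CCCc3nnn[nH]3)cc2)ccc(C(C)=O)c1O`, 7.67
compound 3, `CCCc1c(COc2ccc(C(=O)CCCCc3nnn[nH]3)cc2)ccc(C(C)=O)c1O`, 7.28

Three compounds share one core and differ only in the length of the chain that carries the tetrazole ring. In a functional assay on ileum (Cavia porcellus) with cysteinyl leukotriene receptor (Homo sapiens) as the target (a lower number here means a less potent compound, a higher number a more potent compound, by a factor of ten per unit of this negative logarithm), compound 1 gives 7.71, compound 2 gives 7.67 and compound 3 gives 7.28. The first lengthening, (2-(1H-tetrazol-5-yl)ethyl in place of 1H-tetrazol-5-yl on a saturated chain carbon bound to a carbonyl carbon), leaves the read-out essentially where it was: a number 0.04 log units lower from compound 1 to compound 2 (within the scatter). Going further, a number 0.43 log units lower from compound 1 to compound 3 (beyond the scatter) and a number 0.39 log units lower from compound 2 to compound 3 (beyond the scatter), so compound 3 has the lowest of the three numbers, beyond the scatter against both others.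

Compound 4, `CCCc1c(COc2ccc(C(=O)CCCCCCc3nnn[nH]3)cc2)ccc(C(C)=O)c1O`, has not been measured in this assay. It arises from compound 3 by 2-(1H-tetrazol-5-yl)ethyl in place of 1H-tetrazol-5-yl on a saturated chain carbon, four bonds along the chain from a carbonyl carbon. This is the same kind of change as that from compound 1 to compound 2, but not the same: there the place was on a saturated chain carbon bound to a carbonyl carbon, here it is on a saturated chain carbon, four bonds along the chain from a carbonyl carbon. The core of compound 3 differs from that of compound 1 by 3-(1H-tetrazol-5-yl)propyl in place of 1H-tetrazol-5-yl on a saturated chain carbon bound to a carbonyl carbon.

Because a number 0.04 log units lower from compound 1 to compound 2 (within the scatter) was flat while a number 0.39 log units lower from compound 2 to compound 3 (beyond the scatter) and a number 0.43 log units lower from compound 1 to compound 3 (beyond the scatter) fell, a further modest decline is expected for compound 4, roughly a number 0.33 log units lower from compound 3 to compound 4 (beyond the scatter). The estimate for compound 4 in this assay is 6.95, expected to lie between 6.45 and 7.45.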

Compound 4, negative logarithm of the antagonist equilibrium constant: 7.33
The estimate for compound 4 lay 0.38 log units below the measured number, within the range that was stated.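

In this assay, adding 2-(1H-tetrazol-5-yl)ethyl in place of 1H-tetrazol-5-yl left the read-out level on the longer chain, with a number 0.05 log units higher from compound 3 to compound 4 (within the scatter), and this matched the same change on the shorter chain: the same change on two cores in this assay, a number 0.04 log units lower (within the scatter) from compound 1 to compound 2 and a number 0.05 log units higher (within the scatter) from compound 3 to compound 4, 0.09 log units apart, within the scatter of two such steps

The larger change, 3-(1H-tetrazol-5-yl)propyl in place of 1H-tetrazol-5-yl, also carried over from one core to another, with a number 0.34 log units lower from compound 2 to compound 4 (beyond the scatter) set against the earlier step on the core of compound 1: the same change on two cores in this assay, a number 0.43 log units lower (beyond the scatter) from compound 1 to compound 3 and a number 0.34 log units lower (beyond the scatter) from compound 2 to compound 4, 0.09 log units apart, within the scatter of two such steps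

Together with a number 0.38 log units lower from compound 1 to compound 4 (beyond the scatter), these steps place compound 3 and compound 4 on a lower level than compound 1 and compound 2, but they rest on only two comparisons among chain lengths, and they do not show that either change would carry over to a core that differs anywhere other than in this chain.

The compounds shown leave open whether a chain longer than that of compound 4 would stay level with it or fall further. They also leave open whether a carboxylic acid in place of the tetrazole, or an amide in place of the chain carbonyl, would follow the same steps.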